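Anilino in place of acetylpiperazine on compound 1

The compounds below may be only part of what the source reports. "The series", "measured", "known", "first", "only" and "open" are said of these compounds alone.

Going by the values given here, in a functional assay on A549 cells (Homo sapiens) for antiproliferative activity, read by spectrophotometry, with a stated time of 2 days (on this read-out higher numbers stand for weaker inhibition of growth and lower numbers for stronger inhibition of growth), compound 1 (`CC(=O)N1CCN(c2ccc(Nc3ncc(C(F)(F)F)c(N4Cc5cccc(N(C)S(C)(=O)=O)c5C4)n3)cc2)CC1`) gives 1300 nM and so holds the lower of the two numbers measured so far. In this assay compound 2 (`COc1cc(N2CCN(C(C)=O)CC2)ccc1Nc1ncc(C(F)(F)F)c(N2Cc3cccc(N(C)S(C)(=O)=O)c3C2)n1`) gives 3300 nM and carries methoxy in place of hydrogen on an aromatic carbon. In this assay compound 3 (`Cc1ccc(Nc2ncc(C(F)(F)F)c(N3Cc4cccc(N(C)S(C)(=O)=O)c4C3)n2)c(Cl)c1`) reports > 30000 nM and this is a limit, not a number.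

Compound 4 (`CN(c1cccc2c1CN(c1nc(Nc3ccc(Nc4ccccc4)cc3)ncc1C(F)(F)F)C2)S(C)(=O)=O`) has not been measured. Its difference from compound 1 (anilino in place of 4-acetylpiperazin-1-yl on an aromatic carbon) is anilino in place of 4-acetylpiperazin-1-yl on an aromatic carbon, para to a large group. Among the compounds with values here, no measured step makes this exchange. Within the data shown here, the only measured step (a 2.5-fold higher number from compound 1 to compound 2 (0.40 log units; beyond the scatter)) is modest and of a different kind, so it offers a rough scale and nothing firmer. Compound 1 at 1300 nM holds the lower number, so a step of similar or somewhat larger size toward a higher number, meaning weaker inhibition of growth, is expected in this assay with wide uncertainty. The estimate is a step of a 2.3-fold higher number from compound 1 to compound 4 (0.36 log units; beyond the scatter) in this direction. Compound 4 is expected at 3000 nM (range 700 nM to 15000 nM).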

Compound 4, concentration for 50% growth inhibition: 6200 nM
Estimate against measurement, compound 4: 2.1-fold (0.32 log units) below; measured number inside the range.
By their numbers in this assay, from the lowest: compound 1; then compounds 2 and 4 (each within the scatter of the next). At a limit, above all of these: compound 3.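

In this assay, putting anilino in place of 4-acetylpiperazin-1-yl gives a 4.8-fold higher number from compound 1 to compound 4 (0.68 log units; beyond the scatter), the first measured sign that growth inhibition responds to the group held at this place, on an aromatic carbon para to a large group. The exchange changes several things at once: a six-membered non-aromatic ring with 2 hetero atoms and a carbonyl goes, while a six-membered aromatic ring of carbon only and a hydrogen-bond donor arrive, so this single step cannot show which of these differences matters. Nothing measured here offers a reason for the weaker inhibition of growth.

The compounds shown leave open whether the acetyl group, the piperazine ring or the whole group is what separates compound 1 from compound 4. A piperazine with a free amine in place of the acetylated one, or a morpholine at the same place, would help to separate these possibilities, since each keeps a six-membered non-aromatic ring while changing what it carries.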